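Difluoromethoxy on the distal ring of compound 3

The compounds below may be only part of what the source reports. "The series", "measured", "known", "first", "only" and "open" are said of these compounds alone.

Measured compounds:
compound 1 `CCCS(=O)(=O)NC(=O)c1cc(COc2ccc(-c3ccc(OC)cc3)cc2)c(C)o1` gives 7 ug/mL
compound 2 `COc1ccc(-c2ccc(OCc3cc(C(=O)NS(=O)(=O)c4c(C)noc4C)oc3C)cc2)nc1` gives 90 ug/mL
compound 3 `Cc1oc(C(=O)NS(=O)(=O)c2ccccc2)cc1COc1ccc(-c2ccccc2)cc1` gives 2 ug/mL

These three compounds were characterised in a physicochemical assay for solubility, in phosphate buffer, with a stated time of 24 h, at pH 7.4; a lower number here means a less soluble compound, a higher number a more soluble compound. Among the numbers shown, compound 3 stands lowest: compound 1 sits above it by a margin that goes beyond the scatter, and compound 2 sits furthest above it. Among the compounds with values here, the three compounds differ from one another in more than one place, so no single step between them can be read from the values; only the values themselves can be compared.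

Compound 4 `Cc1oc(C(=O)NS(=O)(=O)c2ccccc2)cc1COc1ccc(-c2ccc(OC(F)F)cc2)cc1` has not yet been measured. It is derived from compound 3 by a single alteration: difluoromethoxy in place of hydrogen on an aromatic carbon. The change sits para to a large group on the outer six-membered aromatic ring of carbon only.

Within the data shown here, nothing among the measured compounds isolates this alteration, so the expected step in this assay from compound 3 to compound 4 is estimated as no change at the digits printed from compound 3 to compound 4 (within the scatter), a step not clearly beyond the scatter in either direction. On that basis compound 4 is estimated at 2 ug/mL, with a range from 0.7 ug/mL to 6 ug/mL.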

Compound 4, solubility: < 0.6 ug/mL
Compound 4: no number, only a limit (the forecaster's own chance of this, stated with the estimate: 10%); middle value at least 3.3-fold (0.52 log units) from the limit.
By their numbers in this assay, from the lowest: compound 3; then compound 1; then compound 2. At a limit, below all of these: compound 4.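

Difluoromethoxy in place of hydrogen on an aromatic carbon of the outer ring, para to a large group, gives an at least 3.3-fold lower number from compound 3 to compound 4 (0.52 log units; beyond the scatter) in this assay, the first step in this set that can be read at a single place. Within the data shown here, compound 4 gives < 0.6 ug/mL, which is a limit of the assay and not a number: the limit of < 0.6 ug/mL in this assay, at which 1 of the 4 values shown sits. The step therefore has a lower bound but no full size, and it shows that this position is not silent in this assay, since even the lowest of the earlier compounds moves further down with this change.

The compounds shown leave open how far compound 4 lies past the limit, and whether the step belongs to difluoromethoxy in particular or to any group at this carbon. Going by these compounds, whether an amine or a carboxylic acid on the same carbon would move the number the other way also stays open.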